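The compounds below may be only part of what the source reports. "The series", "measured", "known", "first", "only" and "open" are said of these compounds alone.

In an ADME assay on microsomes from liver (Rattus norvegicus) for metabolic stability, with a stated time of 10 min, tested at 0.5 uM (a lower number here means that less of the compound is left, a higher number that more of the compound is left), compound 3, `Cn1cc(-c2ccc(C(F)(F)F)cc2)c2cc(F)c(C(=O)NS(C)(=O)=O)cc21`, gives 99%, and compound 1, `Cn1cc(-c2ccc(C(F)(F)F)cc2)c2cc(F)c(C(=O)NS(=O)(=O)C3CC3)cc21`, gives 100%. These two differ in one place: cyclopropyl in place of methyl on a sulfonyl sulfur. That change made a step of a number 1 percentage points higher from compound 3 to compound 1 (within the scatter), so the two numbers cannot be told apart. Compound 2, `CC(C)COc1ccc(-c2cn(C)c3cc(C(=O)NS(C)(=O)=O)c(F)cc23)cn1`, gives 98% in this assay; how its core differs from the core of compound 3 is not broken down here, and the two values simply sit close together. Compound 4, `CC(C)COc1ccc(-c2cn(C)c3cc(C(=O)NS(=O)(=O)C4CC4)c(F)cc23)cn1`, has not yet been measured. It stands to compound 2 as compound 1 stands to compound 3, the change being the same one: cyclopropyl in place of methyl on a sulfonyl sulfur. Because the earlier instance of this change gave only a number 1 percentage points higher from compound 3 to compound 1 (within the scatter), and because compound 2 already sits at 98% in this assay, a step of about no change at the digits printed from compound 2 to compound 4 (within the scatter) is expected, which would stay within the usual scatter. On that basis compound 4 is estimated to give roughly 98% in this assay, most plausibly between 91% and 100%.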

Compound 4, percent of the compound remaining: 78%
Compound 4: the middle estimate sits 20 percentage points above what was measured; the whole stated range lies above it.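

In this assay, putting cyclopropyl in place of methyl on the sulfonyl sulfur gave a number 20 percentage points lower from compound 2 to compound 4 (beyond the scatter). The same swap therefore does not bring the same step on both cores, so the result on one core cannot simply be carried over to the other: the same change on two cores in this assay, a number 1 percentage points higher (within the scatter) from compound 3 to compound 1 and a number 20 percentage points lower (beyond the scatter) from compound 2 to compound 4, 21 percentage points apart, beyond the scatter of two such steps This rests on just one pair of compounds per core, and it does not show which feature of the core of compound 2 goes with the lower number, why less of compound 4 is left, or whether other cores would follow either pair.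

The compounds shown leave open whether another group on the sulfonyl sulfur, such as ethyl or a longer chain, would also lower the number on the core of compound 2, or whether this drop belongs to cyclopropyl alone. They also leave open how the swap from methyl to cyclopropyl would behave on a third core.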